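Swapping dimethylamino for a thiophenylmethylamino: cytotoxicity outlook

The source may report more compounds than this note shows. Statements on the series, on what has been measured and on what is new or still open speak of the compounds shown alone.

Compound 1, `CNc1ccc2sc(-c3c(Cl)nc(N)nc3N[C@@H]3C[C@H](CO)[C@@H](O)[C@H]3O)nc2c1`: 20000 nM
Compound 2, `Cc1nc(N(C)C)nc(N[C@@H]2C[C@H](CO)[C@@H](O)[C@H]2O)c1-c1nc2ccccc2s1`: 18000 nM
Compound 3, `CCc1nc(N(C)C)nc(N[C@@H]2C[C@H](CO)[C@@H](O)[C@H]2O)c1-c1nc2ccccc2s1`: > 25000 nM, a limit of the assay

Of the compounds shown here, three have been measured in an ADME assay on cells (Homo sapiens) for cytotoxicity, read by polymerase chain reaction, with a stated time of 3 days; a lower number here means that less compound is tolerated, a higher number that more compound is tolerated. Compound 2 stands lowest of the two numbers with 18000 nM, yet compound 1 with 20000 nM sits within the usual scatter of it. Compound 3 gives only a limit of the assay, (the limit of > 25000 nM in this assay, at which 1 of the 3 values shown sits). Compound 4 is `Cc1nc(NCc2ccsc2)nc(N[C@@H]2C[C@H](CO)[C@@H](O)[C@H]2O)c1-c1nc2ccccc2s1`; it differs from compound 2 by ((thiophen-3-yl)methyl)amino in place of dimethylamino on an aromatic carbon. Among the compounds with values here, the single measured step, an at least 1.3-fold higher number from compound 2 to compound 3 (0.14 log units; that floor lies within the scatter), alters a different group, so no measured step bears directly on this change. A step of a 1.2-fold lower number from compound 2 to compound 4 (0.08 log units; within the scatter) is therefore expected, nothing beyond the scatter. Compound 4 is estimated at 15000 nM, with a range from 6000 nM to 30000 nM.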

Compound 4, half-maximal cytotoxic concentration: 6000 nM
Estimate against measurement, compound 4: 2.5-fold (0.40 log units) above, within the range that was stated.
By their numbers in this assay, from the lowest: compound 4; then compounds 2 and 1 (each within the scatter of the next). At a limit, above all of these: compound 3.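

Within the data shown here, the position between two ring nitrogen atoms is the first place in this set where a single change moves the number in this assay beyond the scatter: a 3.0-fold lower number from compound 2 to compound 4 (0.48 log units; beyond the scatter). The modest step shows that less compound is tolerated with ((thiophen-3-yl)methyl)amino, which brings an aromatic ring and a hydrogen-bond donor, than with dimethylamino. Nothing measured here accounts for this step.

As far as these compounds go, it remains open whether the thiophene ring, the amine hydrogen or the overall size of the group matters. Benzylamino or ethylamino at this position could help separate these features.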